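This account rests on a few compounds, and the source may have more. Where it says the series, first, only, none or still open, it means among the compounds named here.

Compound 1 `Nc1nc2ccccn2c1-c1ccc(O)cc1` was examined in an assay on isolated protein for inhibition of ubiquitin carboxyl-terminal hydrolase 47 (Homo sapiens); a higher number here means a weaker inhibitor, a lower number a stronger inhibitor. In this assay compound 1 returns only a limit of the assay, > 100000 nM, so its place on the scale is not a number but a boundary. Two near relatives were measured as well. Compound 2 `CC(C)Nc1nc2ccccn2c1-c1ccc(O)cc1` carries an isopropyl group on a nitrogen of the core in place of a hydrogen, and in this assay compound 2 also returns the limit > 100000 nM. Compound 3 `Nc1nc2ccc(C(F)(F)F)cn2c1-c1ccc(O)cc1` carries a trifluoromethyl group on an aromatic carbon of the core in place of a hydrogen, and in this assay compound 3 likewise returns the limit > 100000 nM. The change a step that the two limits leave unreadable from compound 1 to compound 2 and the change a step that the two limits leave unreadable from compound 1 to compound 3 cannot be read in size or direction because of the limit of > 100000 nM in this assay, at which 3 of the 3 values shown sit. Compound 4 `Cc1ccn2c(-c3ccc(O)cc3)c(N)nc2c1` is the next relative: methyl in place of hydrogen on an aromatic carbon. Neither measured step gives a readable size, so no direction can be borrowed from them, and nothing among the three measured compounds points toward a result that leaves the limit. The step of a number no higher from compound 1 to compound 4 (the limit leaves the size open) is therefore the expected outcome. Compound 4 is expected to show 100000 nM in this assay, with a range from 30000 nM to 300000 nM.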

Compound 4, half-maximal inhibitory concentration: > 100000 nM
Compound 4: only a limit was reported; the forecaster's own chance of this, stated with the estimate: 85%; the middle value lies on the limit itself.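

Compound 4, like compound 1, gives only a limit in this assay, so no size or direction can be read for the step from hydrogen to methyl between these two compounds: the limit of > 100000 nM in this assay, at which 4 of the 4 values shown sit.

The compounds shown leave open whether any change to the shared core can give a measurable inhibition value, and which groups would matter for it.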